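The source may hold more compounds than are shown below. What is called first, only, known or untested is meant among the compounds shown, and "the series" means these compounds.

Measured in a functional assay on HCT-116 cells (Homo sapiens) for cytotoxicity, read by sulforhodamine B assay, with a stated time of 48 h; a lower number here means a stronger inhibitor of growth, a higher number a weaker inhibitor of growth:
compound 1 `ClCc1ccccc1Cn1cnc2c(Cl)nc(Cl)nc21` gives 380 nM
compound 2 `ClCc1ccccc1Cn1cnc2c(Cl)ncnc21` gives 3710 nM
compound 3 `ClCc1cccc(Cn2cnc3c(Cl)ncnc32)c1` gives 3090 nM

Compound 1 and compound 2 share a core and differ in one place, (chloro in place of hydrogen on an aromatic carbon). That change gave a 9.8-fold lower number from compound 2 to compound 1 (0.99 log units; beyond the scatter). Compound 3 is built from the same atoms as compound 2, joined differently; the difference between the two cores is not broken down here. Compound 4 `ClCc1cccc(Cn2cnc3c(Cl)nc(Cl)nc32)c1` has not yet been measured in this assay. It differs from compound 3 by chloro in place of hydrogen on an aromatic carbon, the same change as that from compound 2 to compound 1, at a place described in the same words. Because the earlier change gave a 9.8-fold lower number from compound 2 to compound 1 (0.99 log units; beyond the scatter), compound 4 is expected to show a step of similar size, a 7.7-fold lower number from compound 3 to compound 4 (0.89 log units; beyond the scatter). Compound 4 is therefore estimated to give about 400 nM in this assay, with a likely range from 150 nM to 1100 nM.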

Compound 4, concentration for total growth inhibition: 3090 nM
Estimate against measurement, compound 4: 7.7-fold (0.89 log units) below; measured number outside the range, above it.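

In this assay, placing a chloro group on the aromatic carbon between two ring nitrogen atoms gave no change at the digits printed from compound 3 to compound 4 (within the scatter). Set beside the earlier step, the same change behaved differently on the two cores: the same change on two cores in this assay, a 9.8-fold lower number (0.99 log units; beyond the scatter) from compound 2 to compound 1 and no change at the digits printed (within the scatter) from compound 3 to compound 4, 9.8-fold (0.99 log units) apart, beyond the scatter of two such steps. This shows that a drop in the number seen on one core cannot be assumed on the other, but two pairs do not show what sets the cores apart or how the change would behave on a further core.

The compounds shown carry only hydrogen or chloro at this place, so the outcome with an amine, a methoxy group or a longer chain there remains open. From the compounds shown here alone, whether bromo or fluoro would separate the two cores in the same way is also open.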